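Moving the Halogen on the Arylidene Phenyl Ring

The source may report more compounds than this note shows. Statements on the series, on what has been measured and on what is new or still open speak of the compounds shown alone.

Measured in a functional assay on MCF7 cells (Homo sapiens) for cytotoxicity, read by MTT assay, with a stated time of 72 h; a higher number here means that more compound is needed for the effect, a lower number that less compound is needed:
Compound 1 `O=C1/C(=C\c2ccc(F)cc2)c2ccccc2N1c1c(Cl)cccc1Cl`: 9 ug/mL
Compound 2 `O=C1/C(=C\c2ccc(O)cc2)c2ccccc2N1c1c(Cl)cccc1Cl`: 20 ug/mL
Compound 3 `O=C1/C(=C\c2cccc(Br)c2)c2ccccc2N1c1c(Cl)cccc1Cl`: 5 ug/mL

Compound 3 gives the lowest of the three numbers in this assay. Its nearest neighbour is compound 1, with a 1.8-fold lower number from compound 1 to compound 3 (0.26 log units; within the scatter), while compound 2 stands furthest away, with a 4.0-fold lower number from compound 2 to compound 3 (0.60 log units; beyond the scatter). Going from compound 1 to compound 2, the change a 2.2-fold higher number from compound 1 to compound 2 (0.35 log units; beyond the scatter) shows that a hydroxy in place of a fluoro on the aromatic carbon costs activity.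

Compound 4 `O=C1/C(=C\c2ccccc2Cl)c2ccccc2N1c1c(Cl)cccc1Cl` is the next step from compound 3. 2-chlorophenyl in place of 3-bromophenyl on a double-bonded chain carbon bound to a double-bonded ring carbon

Going by the values given here, the step that bears most directly on this change is the one from compound 1 to compound 3, where one halogen-bearing phenyl replaced another and a 1.8-fold lower number from compound 1 to compound 3 (0.26 log units; within the scatter) stayed within the scatter. The larger shift seen from compound 2 to compound 3 involved a hydroxy group, which is absent here, so it is less informative. A halogen-to-halogen exchange on the same phenyl ring is therefore expected to give a step of a 1.2-fold higher number from compound 3 to compound 4 (0.08 log units; within the scatter) in this assay, that is, no movement beyond the scatter. Compound 4 is estimated at 6 ug/mL, within a range of 3 ug/mL to 14 ug/mL.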

Compound 4, concentration for half-maximal effect: 9 ug/mL
Compound 4: middle estimate off by 1.5-fold (0.18 log units), on the low side; the measured number falls inside the stated range.
By their numbers in this assay, from the lowest: compounds 3, 1 and 4 (each within the scatter of the next); then compound 2.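

With the 2-chlorophenyl group, a third halogen-bearing phenyl joins the series, and in this assay it stays level with the other two, showing a 1.8-fold higher number from compound 3 to compound 4 (0.26 log units; within the scatter) and no change at the digits printed from compound 1 to compound 4 (within the scatter). Going by these compounds alone, compounds 1, 3 and 4 therefore show that this place on the double-bonded chain carbon tolerates a change of both the halogen and where it sits on the phenyl ring, with no step among them beyond the scatter, although each of these steps alters both features at once and cannot separate them. Compound 2 remains apart from all three halogen-bearing compounds, and the new comparison adds a 2.2-fold lower number from compound 2 to compound 4 (0.35 log units; beyond the scatter), while no measured evidence explains either the flat halogen steps or this gap.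

The compounds shown leave open whether the gap belongs to the hydroxy group alone or would also appear with an amine, a carboxylic acid or a methoxy group on this phenyl ring. They also leave open what a single halogen would do when moved around the ring on its own, and how an unsubstituted phenyl would compare.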